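From Thiophen-2-yl to 4-Fluorophenyl on a Shared Core

A few compounds are considered here, and "the series" means these few. Any claim that something is new, unique, unknown or untested is made for them only; others in the source may bear on it.

Two measured compounds share one core. Compound 1 `Cc1nnc(COc2cnn(C(C)(C)C)c(=O)c2Cl)o1` carries a methyl on an aromatic carbon, while compound 2 `CC(C)(C)n1ncc(OCc2nnc(-c3cccs3)o2)c(Cl)c1=O` carries thiophen-2-yl at that position. In a functional assay on the whole organism for inhibition, with Mythimna separata as the target, with a stated time of 5 days (on this read-out higher numbers stand for an effect only at larger amounts of compound and lower numbers for an effect already at smaller amounts), compound 1 gives > 300 ug/mL, which is a limit of the assay rather than a number. In this assay compound 2 likewise gives only a limit, > 300 ug/mL. The step that the two limits leave unreadable from compound 1 to compound 2 cannot be read, and compound 2 stands at the limit of > 300 ug/mL in this assay, at which 2 of the 2 values shown sit. Compound 3 `CC(C)(C)n1ncc(OCc2nnc(-c3ccc(F)cc3)o2)c(Cl)c1=O` is not yet measured; it differs from compound 2 by 4-fluorophenyl in place of thiophen-2-yl on an aromatic carbon. Among the compounds with values here, no measured step covers this change, and the known results give no direction to lean on. The expected step that the limit leaves unreadable from compound 2 to compound 3 is therefore none beyond the scatter, with a limit again the most likely outcome. Compound 3 is estimated at 400 ug/mL, within a range from 150 ug/mL to 1500 ug/mL.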

Compound 3, half-maximal effective concentration: 5.2 ug/mL
Beside the measured number, compound 3's estimate is 77-fold (1.89 log units) above it; the whole stated range lies above it.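

The earlier pair could not show whether the group on this aromatic carbon matters at all, and the step between methyl and thiophen-2-yl cannot be read: the limit of > 300 ug/mL in this assay, at which 2 of the 3 values shown sit. Compound 3 now shows that it does matter in this assay: 4-fluorophenyl in place of thiophen-2-yl gives an at least 57-fold lower number from compound 2 to compound 3 (1.76 log units; beyond the scatter), and 4-fluorophenyl in place of methyl gives an at least 57-fold lower number from compound 1 to compound 3 (1.76 log units; beyond the scatter). The two aromatic rings are therefore not interchangeable here, and thiophen-2-yl shows that just any aromatic ring on this carbon is not enough.

The compounds shown cannot separate the part played by the fluorine from that of the six-membered ring of carbon only, and a plain phenyl would be the direct test. They also leave open how a chlorine on that ring, a methoxy group or an amine would fare at this place.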